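Swapping the sulfonyl ring: thiophene out, methoxypyridine in

The source may report more compounds than this note shows. Statements on the series, on what has been measured and on what is new or still open speak of the compounds shown alone.

Measured so far:
compound 1 `CNCc1cc(-c2cccnc2)n(S(=O)(=O)c2ccccc2)c1` gives 0.08 in a physicochemical assay for lipophilicity, read by HPLC, at pH 7.4; on this read-out higher numbers stand for higher lipophilicity and lower numbers for lower lipophilicity
compound 2 `CNCc1cc(-c2cccnc2F)n(S(=O)(=O)c2ccsc2)c1` gives -0.83 in this assay

Of the two numbers, compound 2 holds the lower one; compound 1 sits higher by a margin beyond the usual scatter. The two compounds differ in more than one place, so only their values, not a single step, can be read from them.

Compound 3 `CNCc1cc(-c2cccnc2F)n(S(=O)(=O)c2ccc(OC)nc2)c1` is not yet measured. It arises from compound 2 by one change: 6-methoxypyridin-3-yl in place of thiophen-3-yl on a sulfonyl sulfur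

For the measured compounds named here, no measured pair shows this exchange, so the expectation rests on the structures alone. In this assay a modest downward step is expected, plausibly beyond the scatter, and the estimated step from compound 2 to compound 3 is a number 0.47 log units lower from compound 2 to compound 3 (beyond the scatter). Compound 3 is therefore expected to give about -1.3, within a range from -2 to -0.6.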

Compound 3, distribution coefficient: 0.24
Compound 3: the middle estimate sits 1.54 log units below what was measured; the whole stated range lies below it.
By their numbers in this assay, from the lowest: compound 2; then compounds 1 and 3 (each within the scatter of the next).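

In this assay, putting 6-methoxypyridin-3-yl in place of thiophen-3-yl on a sulfonyl sulfur gives a number 1.07 log units higher from compound 2 to compound 3 (beyond the scatter). For the compounds shown here, this is the first comparison here that differs in only one place, so it shows that the group on the sulfonyl sulfur can by itself shift this read-out by a large amount, and that the shift here is upward. No measurement at hand explains the direction or size of this step.

The exchange alters the ring and adds the methoxy group together, so this single pair cannot show how much of the step belongs to each. It also leaves open how the read-out would respond at this position to an ethoxy group or an amine in place of the methoxy group, or to a carboxylic acid on the ring.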